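This account rests on a few compounds, and the source may have more. Where it says the series, first, only, none or still open, it means among the compounds named here.

Compound 1 `CCC(CC)n1c(-c2ccc(OCc3c(-c4c(Cl)cccc4Cl)noc3C(C)C)cc2)nc2ccc(C(=O)O)cc21` sits lowest of the three numbers measured in an assay on Huh-7 cells for agonist activity at Bile acid receptor (Homo sapiens), read by a luciferase reporter (a higher number here means that more compound is needed for the effect, a lower number that less compound is needed), where compound 1 gives 0.8 nM. Its nearest neighbour is compound 2 `CC(C)c1onc(-c2c(Cl)cccc2Cl)c1COc1ccc(-c2nc3ccc(C(=O)O)cc3n2C(C)C)cc1`, which in this assay gives 3.39 nM; the step is a 4.2-fold higher number from compound 1 to compound 2 (0.63 log units; beyond the scatter). Far behind lies compound 3 `CC(=O)N1CCC(n2c(-c3ccc(OCc4c(-c5c(Cl)cccc5Cl)noc4C(C)C)cc3)nc3ccc(C(=O)O)cc32)CC1`, which gives 1430 nM; the step from compound 1 is a 1800-fold higher number from compound 1 to compound 3 (3.25 log units; beyond the scatter), and from compound 2 it is a 420-fold higher number from compound 2 to compound 3 (2.63 log units; beyond the scatter).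

Compound 4 `CCCC(CCC)n1c(-c2ccc(OCc3c(-c4c(Cl)cccc4Cl)noc3C(C)C)cc2)nc2ccc(C(=O)O)cc21` differs from compound 1 by 1-propylbutyl in place of pentan-3-yl on an aromatic nitrogen. Among the compounds with values here, two measured steps bear on changes at this position. Shrinking the chain to isopropyl, as in the step of a 4.2-fold higher number from compound 1 to compound 2 (0.63 log units; beyond the scatter), cost a little; bringing in 1-acetylpiperidin-4-yl, as in a 1800-fold higher number from compound 1 to compound 3 (3.25 log units; beyond the scatter), cost a great deal. Within the data shown here, no measured compound tells what lengthening the chain does, so a small step is expected, possibly none beyond the scatter, most likely toward a slightly higher number: for compound 4 the expected step is a 1.6-fold higher number from compound 1 to compound 4 (0.21 log units; within the scatter). Compound 4 is therefore estimated at 1.3 nM, within a range from 0.4 nM to 5 nM.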

Compound 4, half-maximal effective concentration: 1.8 nM
Estimate against measurement, compound 4: 1.4-fold (0.14 log units) below; measured number inside the range.
By their numbers in this assay, from the lowest: compound 1; then compounds 4 and 2 (each within the scatter of the next); then compound 3.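

Lengthening the chain also costs something, with a 2.3-fold higher number from compound 1 to compound 4 (0.35 log units; beyond the scatter) in this assay for 1-propylbutyl in place of pentan-3-yl. Pentan-3-yl therefore gives a lower number than both the shorter isopropyl and the longer 1-propylbutyl, while a 1.9-fold lower number from compound 2 to compound 4 (0.27 log units; within the scatter) leaves those two groups indistinguishable in this assay. The large penalty does not appear with the longer all-carbon chain, as a 790-fold lower number from compound 3 to compound 4 (2.90 log units; beyond the scatter) shows when 1-propylbutyl replaces 1-acetylpiperidin-4-yl.

The compounds shown leave open how a cyclopentyl ring, or a chain carrying a hydroxyl or an amine, would behave on this nitrogen, and whether the high number of compound 3 goes with its acetyl group or its piperidine ring. No evidence at hand explains why the number rises on both sides of pentan-3-yl.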